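Bromo for Chloro on Two Thiourea Cores

This account rests on a few compounds, and the source may have more. Where it says the series, first, only, none or still open, it means among the compounds named here.

Measured compounds:
compound 1, `COc1cc(CNC(=S)NCC(COC(=O)C(C)(C)C)Cc2ccc(C)c(C)c2)c(Cl)cc1O`: 24.2 nM
compound 2, `COc1cc(CNC(=S)NCC(COC(=O)C(C)(C)C)Cc2ccc(C)c(C)c2)c(Br)cc1O`: 19.9 nM
compound 3, `COc1cc(CNC(=S)NC(CCc2ccc(C)c(C)c2)COC(=O)C(C)(C)C)cc(Cl)c1O`: 86 nM

In an assay on CHO cells for displacement of a labelled ligand from transient receptor potential cation channel subfamily V member 1 (Rattus norvegicus) (on this read-out higher numbers stand for weaker inhibition and lower numbers for stronger inhibition), compound 3 gives the highest of the three numbers. Compound 1 and compound 3 share the same atoms joined differently; the difference between the two cores is not broken down here. Compound 2 differs from compound 1 by bromo in place of chloro on an aromatic carbon, and the step was a 1.2-fold lower number from compound 1 to compound 2 (0.08 log units; within the scatter). Compound 4, `COc1cc(CNC(=S)NC(CCc2ccc(C)c(C)c2)COC(=O)C(C)(C)C)cc(Br)c1O`, differs from compound 3 by bromo in place of chloro on an aromatic carbon. This is the same kind of change, not the same: in compound 1 the site is ortho to a large group, meta to a hydroxy group and para to a methoxy group, whereas in compound 3 it is ortho to a hydroxy group, meta to a large group and meta to a methoxy group. Because a 1.2-fold lower number from compound 1 to compound 2 (0.08 log units; within the scatter) was within the scatter, a similarly small step a 1.1-fold lower number from compound 3 to compound 4 (0.06 log units; within the scatter) is expected. Compound 4 is therefore estimated at 75 nM, between 35 nM and 160 nM.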

Compound 4, inhibition constant: 102 nM
Compound 4: the middle estimate sits 1.4-fold (0.13 log units) below what was measured, and the stated range covers the measured number.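

In this assay, bromo in place of chloro on the core of compound 3 gave a 1.2-fold higher number from compound 3 to compound 4 (0.07 log units; within the scatter), so the swap again stayed within the scatter. Set beside the earlier step, the change carried from one core to the other with no difference that can be told apart: the same change on two cores in this assay, a 1.2-fold lower number (0.08 log units; within the scatter) from compound 1 to compound 2 and a 1.2-fold higher number (0.07 log units; within the scatter) from compound 3 to compound 4, 1.4-fold (0.16 log units) apart, within the scatter of two such steps. This shows only that the two halogens could be exchanged on these two cores, with the halogen at a different place on each ring; it does not show that a step beyond the scatter would carry over in the same way.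

From the compounds shown here alone, what remains open is whether iodo or a nitrile at this site would give a larger step. Going by these compounds, it also remains open whether such a step would match on both cores.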